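Allyl to ethyl: from compound 1 to compound 4

The source may hold more compounds than are shown below. What is called first, only, known or untested is meant among the compounds shown, and "the series" means these compounds.

Compound 1 `C=CCn1ncc2c(C)nc(CC)n2c1=O` is recorded in a functional assay for inhibition, with Homo sapiens as the target (on this read-out lower numbers stand for stronger inhibition and higher numbers for weaker inhibition), only as a limit, > 48000 nM. Compound 2 `C=CCn1ncc2c(C)nc(C(C)C)n2c1=O` likewise reaches only a limit in this assay, > 48000 nM. Compound 3 `C=CCn1ncc2c(C)nc(C)n2c1=O` gives 73000 nM in this assay. The step that the two limits leave unreadable from compound 1 to compound 2 cannot be sized, nor can the step that the limit leaves unreadable from compound 1 to compound 3, and the step that the limit leaves unreadable from compound 2 to compound 3 is in the same case. Compound 1 therefore stands on a limit alone, as the limit of > 48000 nM in this assay, at which 2 of the 3 values shown sit, makes plain.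

Compound 4 `CCc1nc(C)c2cnn(CC)c(=O)n12` differs from compound 1 by methyl in place of vinyl on a saturated chain carbon bound to an aromatic nitrogen; read one bond further out, the change is allyl to ethyl. Among the compounds with values here, no measured step touches this place: the measured steps concern the other saturated chain carbons and the aromatic carbon, and none of them yields a readable size. The step that the limit leaves unreadable from compound 1 to compound 4 is therefore expected to stay within the scatter in this assay. Compound 4 is estimated at 60000 nM, with a range from 30000 nM to 150000 nM, most probably reported again as a limit.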

Compound 4, half-maximal inhibitory concentration: 75600 nM
The estimate for compound 4 lay 1.3-fold (0.10 log units) below the measured number; low and high end bracket the measured number.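

Within the data shown here, no step from compound 1 to compound 4 can be read in this assay, because compound 1 is recorded only as a limit: the limit of > 48000 nM in this assay, at which 2 of the 4 values shown sit.

The compounds shown leave open whether the change from allyl to ethyl alters inhibition in this assay at all, and in which direction.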